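A few compounds are considered here, and "the series" means these few. Any claim that something is new, unique, unknown or untested is made for them only; others in the source may bear on it.

From the compounds shown here alone, in a functional assay on HCT-116 cells (Homo sapiens) for inhibition, read by MTT assay, with a stated time of 72 h (on this read-out higher numbers stand for weaker inhibition and lower numbers for stronger inhibition), compound 1 `Nc1ncnc2c1c(-c1cnc3[nH]ccc3c1)nn2CC(=O)NO` stands only at a limit, > 150000 nM, so its true position is unknown. Compound 2 `Nc1nc2cc(-c3nn(CCC(=O)NO)c4ncnc(N)c34)ccc2o1` also gives only a limit, > 100000 nM. Compound 3 `Nc1ncnc2c1c(-c1cnc3[nH]ccc3c1)nn2CCCCCCC(=O)NO` has the core of compound 1, with 5-(hydroxycarbamoyl)pentyl in place of hydroxycarbamoyl on a saturated chain carbon bound to an aromatic nitrogen. Among the measured compounds shown here, no measured step in this assay bears on this change, so the expectation rests on the structural change alone. Stronger inhibition is expected, with an estimated at least 75-fold lower number from compound 1 to compound 3 (1.87 log units; beyond the scatter). For compound 3 the estimated value is 2000 nM, with an expected range of 300 nM to 15000 nM.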

Compound 3, half-maximal inhibitory concentration: 9860 nM
Beside the measured number, compound 3's estimate is 4.9-fold (0.69 log units) below it; the measured number falls inside the stated range.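

In this assay, among the compounds shown here, the place on a saturated chain carbon bound to an aromatic nitrogen now gives a first number that is not a limit: 5-(hydroxycarbamoyl)pentyl in place of hydroxycarbamoyl gives an at least 15-fold lower number from compound 1 to compound 3 (1.18 log units; beyond the scatter). On the core of compound 1, the chain carrying the hydroxycarbamoyl end therefore matters in this assay. The step is only a minimum, since compound 1 stands at a limit: the limit of > 150000 nM in this assay, at which 1 of the 3 values shown sits.

Still open, from the compounds shown here alone, is whether a longer chain would lower the number further, or whether a shorter one would already suffice. Also open, going by these compounds, is whether a carboxylic acid could replace the hydroxycarbamoyl end on this chain.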